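A butyl ether after three limits

The compounds below may be only part of what the source reports. "The series", "measured", "known", "first", "only" and "open" are said of these compounds alone.

Measured in a functional assay on L1210 (1565) cells (Mus musculus) for cytotoxicity; a higher number here means that more compound is needed for the effect, a lower number that less compound is needed

Compound 1 `CCOc1cc(-c2ccccc2)nc2ccccc12` gives > 10 ug/mL
Compound 2 `CC(C)Oc1cc(-c2ccccc2)nc2ccccc12` gives > 10 ug/mL
Compound 3 `CCCOc1cc(-c2ccccc2)nc2ccccc12` gives > 10 ug/mL

Compound 3 stands at > 10 ug/mL in this assay, which is a limit of the assay and not a number. Within the data shown here, the series so far offers only the limit of > 10 ug/mL in this assay, at which 3 of the 3 values shown sit, and no readable value.

The next compound is compound 4 `CCCCOc1cc(-c2ccccc2)nc2ccccc12`, and the change from compound 3 is methyl in place of hydrogen on a saturated chain carbon, three bonds along the chain from an oxygen on an aromatic ring, which turns propyl to butyl. The closest measured parallel is a step that the two limits leave unreadable from compound 1 to compound 3, where a methyl also enters in place of a hydrogen on the chain. The two remaining measured steps, a step that the two limits leave unreadable from compound 1 to compound 2 and a step that the two limits leave unreadable from compound 2 to compound 3, give no size either.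

From the compounds shown here alone, with no readable size to carry over from compound 1 and compound 3, no step beyond the scatter is expected, and the direction stays open. The estimated outcome is a step that the limit leaves unreadable from compound 3 to compound 4 in this assay as it stands. Compound 4 is estimated at 14 ug/mL, with an expected range from 6 ug/mL to 30 ug/mL and a good chance of another limit.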

Compound 4, half-maximal effective concentration: > 10 ug/mL
Compound 4: only a limit was reported; the forecaster's own chance of this, stated with the estimate: 75%; the middle value is on the limit's open side.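

No step from compound 1, compound 2 or compound 3 to compound 4 can be read, because the series rests on a limit of the assay and not on numbers: the limit of > 10 ug/mL in this assay, at which 4 of the 4 values shown sit.

The compounds shown leave open how the chain on the oxygen bears on the read-out in this assay.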